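Shortening the ether tail on the quinoxaline dioxide core

The source may report more compounds than this note shows. Statements on the series, on what has been measured and on what is new or still open speak of the compounds shown alone.

Compound 1 `COc1ccc2c(c1)[n+]([O-])nc(NCOC(C)c1ccccc1)[n+]2[O-]`: 740 nM
Compound 2 `[O-][n+]1nc(NCOC2CCCCC2)[n+]([O-])c2ccccc21`: 4170 nM
Compound 3 `COc1ccc2c(c1)[n+]([O-])nc(NCOCc1ccccc1)[n+]2[O-]`: 1190 nM

Among the three compounds measured in a functional assay on SMMC-7721 cells (Homo sapiens) for cytotoxicity, read by MTT assay, with a stated time of 72 h (a lower number here means a stronger inhibitor, a higher number a weaker inhibitor), compound 2 stands with the highest number, beyond the scatter from both compound 3 and compound 1, so it is the weakest inhibitor of the set. Compound 4 `CCCOCNc1n[n+]([O-])c2ccccc2[n+]1[O-]` is obtained from compound 2 by the change (propyl in place of cyclohexyl on an oxygen on a saturated carbon). Among the compounds with values here, the only step measured between two compounds differing in one place is the one from compound 1 to compound 3, a 1.6-fold higher number from compound 1 to compound 3 (0.21 log units; within the scatter), which concerns the carbon next to the oxygen rather than the group on the oxygen, and it stayed within the scatter. Compound 2 and compound 3 differ in two places at once, so their values show only that the cyclohexyl bearer is the weaker of the two. Within the data shown here, with no step directly bearing on a propyl for cyclohexyl exchange, compound 4 is expected to sit near compound 2, with at most a modest drift toward a higher number, a 1.3-fold higher number from compound 2 to compound 4 (0.12 log units; within the scatter). Compound 4 is therefore estimated at 5500 nM, within 2000 nM to 15000 nM.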

Compound 4, half-maximal inhibitory concentration: 5530 nM
Beside the measured number, compound 4's estimate is 1.0-fold (0.00 log units) below it, and the stated range covers the measured number.
By their numbers in this assay, from the lowest: compounds 1 and 3 (each within the scatter of the next); then compounds 2 and 4 (each within the scatter of the next).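

In this assay, within the data shown here, this is the first measured step at the group on the oxygen itself, and it gives a 1.3-fold higher number from compound 2 to compound 4 (0.12 log units; within the scatter). Within this pair, then, the six-membered carbon ring can be exchanged for an open propyl chain with no ring and the two compounds still read alike, so the ring shows no measurable advantage over propyl at this place. Nothing at hand explains why the two compounds read alike.

The compounds shown leave open whether a longer chain such as octyl, or a propyl chain ending in an amine or a carboxylic acid, would stay level with compound 4. They also leave open whether the same exchange of cyclohexyl for propyl would read the same on the methoxy-bearing core of compound 1.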